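The compounds below may be only part of what the source reports. "The series", "measured", "known", "first", "only" and "open" are said of these compounds alone.

Compound 1 `COc1ccc(CNc2nc3cc(N)cc(N)c3nc2-c2ccccc2)cc1OC` is the weaker-looking of the two measured compounds in a functional assay on SK-MEL-28 cells (Homo sapiens) for inhibition, read by sulforhodamine B assay, with a stated time of 48 h (on this read-out higher numbers stand for weaker inhibition of growth and lower numbers for stronger inhibition of growth), where compound 1 gives 13500 nM. Its nearest neighbour is compound 2 `COc1cc(CNc2nc3cc(N)cc(N)c3nc2-c2ccccc2)cc(OC)c1OC`, which in this assay gives 8510 nM; the change from compound 1 to compound 2 is a methoxy in place of hydrogen on an aromatic carbon and gives a 1.6-fold lower number from compound 1 to compound 2 (0.20 log units; within the scatter), a step that stays within the scatter. Compound 3 `COc1ccc(CNc2nc3cc(N)cc(N)c3nc2-c2ccccc2)cc1` is the unmeasured partner of compound 1: the difference is hydrogen in place of methoxy on an aromatic carbon, ortho to a methoxy group and meta to a large group, so that a 3,4-dimethoxyphenyl becomes a 4-methoxyphenyl. Going by the values given here, only the step from compound 1 to compound 2 bears on this change, and it runs the other way, adding a methoxy where compound 3 loses one; since that step was within the scatter, no step beyond the scatter is expected in this assay from compound 1 to compound 3, a 1.2-fold higher number from compound 1 to compound 3 (0.07 log units; within the scatter). Compound 3 is therefore estimated at 16000 nM, with a range from 6000 nM to 45000 nM.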

Compound 3, concentration for 50% growth inhibition: 17400 nM
Compound 3: middle estimate off by 1.1-fold (0.04 log units), on the low side; the range from low to high includes it.
By their numbers in this assay, from the lowest: compounds 2, 1 and 3 (each within the scatter of the next, the first and the last beyond it).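

Compound 3 shows what happens when a methoxy is lost from the ring rather than gained: in this assay, the change from 3,4-dimethoxyphenyl to 4-methoxyphenyl gives a 1.3-fold higher number from compound 1 to compound 3 (0.11 log units; within the scatter). The earlier pair showed only an added methoxy, a 1.6-fold lower number from compound 1 to compound 2 (0.20 log units; within the scatter), and said nothing about this carbon, ortho to a methoxy group and meta to a large group. Here, the methoxy on this carbon can be replaced by hydrogen without a step beyond the scatter, so in these compounds growth inhibition in this assay does not measurably depend on that group. Nothing available accounts for this result or tests what lies behind it.

The compounds shown leave open whether a hydroxyl, an amine or a carboxylic acid on this same carbon would give a step beyond the scatter. They also leave open whether the methoxy that remains in compound 3 could be replaced by hydrogen or by a longer chain such as butoxy with as little consequence.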